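The source may report more compounds than this note shows. Statements on the series, on what has been measured and on what is new or still open speak of the compounds shown alone.

Compounds measured so far:
compound 1, `Cc1cc(S(N)(=O)=O)ccc1NC(=O)COc1ccc(Cl)cc1NC(=O)c1ccccc1`, 207000 nM 
compound 2, `Cc1cc(S(N)(=O)=O)ccc1NC(=O)COc1ccc(Cl)cc1NC(=O)c1cccc(F)c1`, 243000 nM 
compound 3, `Cc1cc(C)cc(C(=O)Nc2cc(Cl)ccc2OCC(=O)Nc2ccc(S(N)(=O)=O)cc2C)c1`, 36500 nM 

Compound 2 carries the highest number of the three in a functional assay on C8166 cells (Homo sapiens) for cytotoxicity, read by MTT assay; on this read-out lower numbers stand for higher toxicity in this test and higher numbers for lower toxicity in this test; compound 1 sits within the scatter of it, while compound 3 lies furthest away, as the step of a 6.7-fold lower number from compound 2 to compound 3 (0.82 log units; beyond the scatter) shows. The new compound 4, `Cc1cc(S(N)(=O)=O)ccc1NC(=O)COc1ccc(Cl)cc1NC(=O)c1cc(Cl)cc(C#N)c1`, differs from compound 2 in one place: 3-chloro-5-cyanophenyl in place of 3-fluorophenyl on a carbonyl carbon.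

Within the data shown here, two measured steps bear on this. The step of a 1.2-fold higher number from compound 1 to compound 2 (0.07 log units; within the scatter), a single fluoro added to the phenyl, changed nothing beyond the scatter. The step of a 6.7-fold lower number from compound 2 to compound 3 (0.82 log units; beyond the scatter), which also exchanges the 3-fluorophenyl for a ring bearing two groups in the 3- and 5-positions, moved the number down modestly. Among the measured compounds shown here, compound 4 likewise brings two groups onto that ring, so a modest downward step is expected, a 2.7-fold lower number from compound 2 to compound 4 (0.43 log units; beyond the scatter), though the groups are not the same and the one comparison is thin. Compound 4 is therefore estimated at 90000 nM, within a range from 30000 nM to 250000 nM.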

Compound 4, half-maximal cytotoxic concentration: 131000 nM
Compound 4: the middle estimate sits 1.5-fold (0.16 log units) below what was measured, within the range that was stated.
By their numbers in this assay, from the lowest: compound 3; then compounds 4, 1 and 2 (each within the scatter of the next).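

In this assay, bringing two groups onto the ring at this position does not by itself lower the number: a 1.9-fold lower number from compound 2 to compound 4 (0.27 log units; within the scatter) and a 1.6-fold lower number from compound 1 to compound 4 (0.20 log units; within the scatter) both stay within the scatter, whereas a 3.6-fold higher number from compound 3 to compound 4 (0.55 log units; beyond the scatter) lies beyond it. Among the compounds shown, then, the lower number goes with the 3,5-dimethylphenyl ring and is not shared by the 3-chloro-5-cyanophenyl ring, so the identity of the groups, not their count, sets compound 3 apart. Nothing available explains why these two rings differ.

From the compounds shown here alone, whether the chloro or the nitrile alone would leave the number where it stands, or a single methyl would already lower it, remains open. Going by these compounds, it is also open what an amine or a carboxylic acid on this ring would do to the number.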